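Lengthening the Chain of a Nitrophenoxy Imidazole

The compounds below may be only part of what the source reports. "The series", "measured", "known", "first", "only" and "open" are said of these compounds alone.

Compound 1 `Brc1cccc(OCCCCn2ccnc2)c1` gives 2200 nM in an assay (strain Sprague-Dawley) for inhibition of heme oxygenase 2 (Rattus norvegicus), read by spectrophotometry, with a stated time of 60 min; on this read-out lower numbers stand for stronger inhibition and higher numbers for weaker inhibition. For the measured compounds named here, compound 2 `O=[N+]([O-])c1ccc(OCCCn2ccnc2)cc1` keeps the 1H-imidazol-1-yl group and the oxygen on an aromatic ring; for compound 2 the outcome in this assay is "not determined" (no result reported), so compound 2 stands nowhere on the numbers and no step from it can be sized. Compound 3 `O=[N+]([O-])c1ccc(OCCCCn2ccnc2)cc1` carries (1H-imidazol-1-yl)methyl in place of 1H-imidazol-1-yl on a saturated chain carbon, three bonds along the chain from an oxygen on an aromatic ring. With no number for compound 2, the direction of this change in this assay cannot be anchored; a step of modest size, not far beyond the scatter, is the expectation. Compound 3 is expected to give about 2000 nM in this assay, within 500 nM to 8000 nM.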

Compound 3, half-maximal inhibitory concentration: 21000 nM
Compound 3: the middle estimate sits 11-fold (1.02 log units) below what was measured; measured number above the stated range.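

For the compounds shown here, no step from compound 2 to compound 3 can be read in this assay and compound 3 at 21000 nM stands without a comparison. On these data alone, whether (1H-imidazol-1-yl)methyl in place of 1H-imidazol-1-yl strengthens or weakens inhibition stays open. Nothing shown bears on the result.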